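Three Limits and a Fourth Aryl Variant

This account rests on a few compounds, and the source may have more. Where it says the series, first, only, none or still open, it means among the compounds named here.

Compound 1 `Cc1ccccc1-c1noc([C@@H]2CCCN2C(=O)Nc2ccc(Cl)cc2)n1`: > 50000 nM
Compound 2 `O=C(Nc1ccc(Cl)cc1)N1CCC[C@H]1c1nc(-c2ccccc2Br)no1`: > 50000 nM
Compound 3 `O=C(Nc1ccc(Cl)cc1)N1CCC[C@H]1c1nc(-c2ccc(Cl)cc2)no1`: > 50000 nM

In an ADME assay on MCF-10A cells (Homo sapiens) for inhibition, with a stated time of 48 h (a lower number here means a stronger inhibitor, a higher number a weaker inhibitor), compound 1 gives only a limit, > 50000 nM, and not a measured number. Compound 2 likewise sits at a limit in this assay. Compound 3 also returns a limit there. The shared core is kept throughout; the three compounds differ only in the aryl group on the five-membered ring. Because (the limit of > 50000 nM in this assay, at which 3 of the 3 values shown sit), none of the steps between them can be read: a step that the two limits leave unreadable from compound 1 to compound 2, a step that the two limits leave unreadable from compound 1 to compound 3 and a step that the two limits leave unreadable from compound 2 to compound 3 are all of unreadable size.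

Compound 4 `O=C(Nc1ccc(Cl)cc1)N1CCC[C@H]1c1nc(-c2ccc(Br)cc2)no1` is not yet measured. It differs from compound 1 as follows: 4-bromophenyl in place of 2-methylphenyl on an aromatic carbon. The measured steps that bear on this change, from compound 1 to compound 2 and from compound 1 to compound 3, were both unreadable, and they cover a halogen on the aryl ring and a move of the substituent to the 4-position. No numbered value anchors any of the three compounds, so no direction of change can be inferred.

Compound 4 is therefore expected to remain at the limit, estimated at 50000 nM with a range of 20000 nM to 200000 nM. The expected step from compound 1 to compound 4 is a number no higher from compound 1 to compound 4 (the limit leaves the size open), meaning no readable change.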

Compound 4, half-maximal inhibitory concentration: > 50000 nM
Compound 4 gave a limit, no number (the forecaster's own chance of this, stated with the estimate: 85%); the middle value lies on the limit itself.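

In this assay compound 4 gives > 50000 nM as a limit and not a number. The steps to compound 4 from compound 1, compound 2 and compound 3 cannot be read, because all four compounds stand at the same limit: the limit of > 50000 nM in this assay, at which 4 of the 4 values shown sit.

The compounds shown leave open whether any of these aryl groups on the shared core gives a measurable half-maximal inhibitory concentration, and how the four compare.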